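Swapping a cyano for a methylsulfonyl on the pyridine

The compounds below may be only part of what the source reports. "The series", "measured", "known", "first", "only" and "open" are said of these compounds alone.

Compound 2 `N#Cc1cccnc1N1CCN(Cc2nc3ccccc3[nH]2)CC1` is a close relative of compound 1 `Fc1cccnc1N1CCN(Cc2nc3ccccc3[nH]2)CC1`. In an assay on HEK293 cells with D(4) dopamine receptor (Homo sapiens) as the target, read by FLIPR (a higher number here means that more compound is needed for the effect, a lower number that less compound is needed), compound 1 gives 24 nM, and compound 2 gives 13.9 nM, which is the lowest of the two numbers, though the step of a 1.7-fold lower number from compound 1 to compound 2 (0.24 log units; within the scatter) is within the scatter. Compound 3 `CS(=O)(=O)c1cccnc1N1CCN(Cc2nc3ccccc3[nH]2)CC1` carries methylsulfonyl in place of cyano on an aromatic carbon. Within the data shown here, no measured step follows this exact change; the only step so far, a swap of one small group for another, was within the scatter. The methylsulfonyl is larger, so a modest rise in the number is expected: a 2.2-fold higher number from compound 2 to compound 3 (0.33 log units; beyond the scatter), giving compound 3 an estimated 30 nM, in the range 8 nM to 110 nM.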

Compound 3, half-maximal effective concentration: 136 nM
Beside the measured number, compound 3's estimate is 4.5-fold (0.66 log units) below it; the measured number lies above the stated range.
By their numbers in this assay, from the lowest: compounds 2 and 1 (each within the scatter of the next); then compound 3.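

In this assay this aromatic carbon turns out not to accept every group equally: fluoro and cyano lie within the scatter of each other, but methylsulfonyl stands clearly apart, with a 9.8-fold higher number from compound 2 to compound 3 (0.99 log units; beyond the scatter) and a 5.7-fold higher number from compound 1 to compound 3 (0.75 log units; beyond the scatter). Among these compounds, both steps lie beyond the scatter, so this is the first change at this position that clearly moves the number. Nothing measured here explains the rise. On these data alone, it remains open how other groups on this carbon, such as a methoxy or an amine, would compare, and whether the rise is particular to methylsulfonyl.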